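From Chloro to Trifluoromethyl on the Aromatic Ring

A few compounds are considered here, and "the series" means these few. Any claim that something is new, unique, unknown or untested is made for them only; others in the source may bear on it.

Measured compounds:
compound 1, `Fc1ccccc1COc1nc2ccccc2s1`: 51.9%
compound 2, `Clc1ccccc1COc1nc2ccccc2s1`: "not active" (no number reported)

In a functional assay on the whole organism with Mus musculus as the target, in the writhing test, at a dose of 100 mg/kg by the intraperitoneal route (a lower number here means less inhibition, a higher number more inhibition at the dose given (going by the name of the read-out)), compound 1 gives 51.9%. In this assay compound 2 gives "not active" (no number reported), so no single number stands for compound 2; only compound 1 carries a measured inhibition. Compound 3 `FC(F)(F)c1ccccc1COc1nc2ccccc2s1` differs from compound 2 by trifluoromethyl in place of chloro on an aromatic carbon. Among the compounds with values here, no measured step links these compounds. Compound 3 is expected to show a modest upward step in this assay, though the range is wide and a report of no activity remains likely. Compound 3 is estimated at 25%, between 0% and 55%.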

Compound 3, a percentage reported as inhibition, in the whole organism at one dose (the size of the read-out at that dose, not a potency): "not active" (no number reported)
Compound 3: no number reported; no gap can be computed for the estimate.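

In this assay compound 3, like compound 2, carries no number, so no step can be read between them. The compounds shown leave open how these two rank against each other. No evidence bears on this result.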